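The source may report more compounds than this note shows. Statements on the series, on what has been measured and on what is new or still open speak of the compounds shown alone.

Compound 2 `CN1CCC[C@H]1[C@H]1COc2ccc(O)cc2O1` carries a hydroxy group on the aromatic ring of the shared core. In an assay on membranes from HEK293 cells for displacement of a labelled ligand from Neuronal acetylcholine receptor; alpha3/beta4 (Homo sapiens), with a stated time of 5 min (on this read-out higher numbers stand for weaker inhibition and lower numbers for stronger inhibition), compound 2 gives 700 nM. Compound 1 `CN1CCC[C@H]1[C@@H]1COc2ccc(N)cc2O1` gives 19 nM in this assay, a lower number, and the gap between the two lies beyond the scatter. Compound 3 `CN1CCC[C@H]1[C@H]1COc2c(O)cccc2O1` gives only a limit in this assay, > 100000 nM, which the report of the limit of > 100000 nM in this assay, at which 1 of the 3 values shown sits, describes; it is a limit and not a number. Among the two numbers that are not limits, compound 2 stands at the higher one.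

Compound 4 `CN(C)c1ccc2c(c1)O[C@@H]([C@@H]1CCCN1C)CO2` differs from compound 2 in one place: dimethylamino in place of hydroxy on an aromatic carbon. Within the data shown here, no step between two measured compounds matches this change, so the size of the step must be judged from the pair alone. Compound 1, which bears a nitrogen substituent on the same ring, gives 19 nM in this assay, so a step downward from compound 2 is expected, though a smaller one. For compound 4 a value of 120 nM is estimated, with a range from 25 nM to 600 nM, which means an expected step of a 5.8-fold lower number from compound 2 to compound 4 (0.77 log units; beyond the scatter).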

Compound 4, inhibition constant: 25000 nM
Beside the measured number, compound 4's estimate is 210-fold (2.32 log units) below it; the measured number lies above the stated range.
By their numbers in this assay, from the lowest: compound 1; then compound 2; then compound 4. At a limit, above all of these: compound 3.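

Among these compounds, this pair gives the first single-place comparison in this assay, and it shows that the group on this aromatic carbon matters: with dimethylamino in place of hydroxy there is a 36-fold higher number from compound 2 to compound 4 (1.55 log units; beyond the scatter), meaning weaker inhibition. The change brings in three heavy atoms for one and removes a hydrogen-bond donor, but both differences arrive together, so this pair cannot separate them. Nothing measured here explains the direction or size of the step.

A methoxy group or a methylamino group on the same aromatic carbon would help show whether the weakening follows the size of the group or the loss of the donor. Going by these compounds, it also remains open whether a plain amine at this place, in the same stereochemical setting as compound 2, would keep or improve the inhibition.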